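This account rests on a few compounds, and the source may have more. Where it says the series, first, only, none or still open, it means among the compounds named here.

Among the compounds with values here, compound 3 `COc1cccc(NC(=O)/C=C/c2coc3cc(OC)ccc3c2=O)c1` is the one compound here with a number rather than a limit: in a functional assay on A549 cells (Homo sapiens) for inhibition, read by MTT assay, with a stated time of 48 h (a lower number here means a stronger inhibitor, a higher number a weaker inhibitor), compound 3 gives 12800 nM. Compound 1 `COc1ccc2c(=O)c(/C=C/C(=O)Nc3ccc(Cl)cc3)coc2c1` carries a 4-chlorophenyl on the amide-type nitrogen; in this assay compound 1 gives > 100000 nM, which is a limit of the assay and not a number. Compound 2 `CCOc1ccc(NC(=O)/C=C/c2coc3cc(OC)ccc3c2=O)cc1` carries a 4-ethoxyphenyl there; in this assay compound 2 gives > 100000 nM, again a limit. Both steps toward compound 3 are therefore readable only as lower bounds: an at least 7.8-fold lower number from compound 1 to compound 3 (0.89 log units; beyond the scatter) and an at least 7.8-fold lower number from compound 2 to compound 3 (0.89 log units; beyond the scatter). Compound 4 `COc1ccc2c(=O)c(/C=C/C(=O)Nc3ccccc3Cl)coc2c1` differs from compound 3 as follows: 2-chlorophenyl in place of 3-methoxyphenyl on an amide-type nitrogen. Two of the three values sit at the limit (the limit of > 100000 nM in this assay, at which 2 of the 3 values shown sit), and the only other chloro-bearing partner, compound 1, gave nothing but that limit. A move back toward weaker inhibition is thus expected, estimated as a 3.9-fold higher number from compound 3 to compound 4 (0.59 log units; beyond the scatter), with a real chance that only a limit is reported. Compound 4 is expected to give about 50000 nM, within 12000 nM to 150000 nM.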

Compound 4, half-maximal inhibitory concentration: 29900 nM
Compound 4: middle estimate off by 1.7-fold (0.22 log units), on the high side; the range from low to high includes it.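

Replacing the 4-chlorophenyl on the amide-type nitrogen with 2-chlorophenyl gives an at least 3.3-fold lower number from compound 1 to compound 4 (0.52 log units; beyond the scatter), so a chloro-bearing ring can yield a real number here, which compound 1 alone could not show. The same ring also stands well against the 4-ethoxyphenyl, with an at least 3.3-fold lower number from compound 2 to compound 4 (0.52 log units; beyond the scatter), so a measurable number at this nitrogen is not confined to the 3-methoxyphenyl of compound 3. The 3-methoxyphenyl still keeps a modest edge over the 2-chlorophenyl, with a 2.3-fold higher number from compound 3 to compound 4 (0.37 log units; beyond the scatter).

On these data alone, how large the two steps starting from limits really are stays open: the limit of > 100000 nM in this assay, at which 2 of the 4 values shown sit. As far as these compounds go, whether the gain follows the chloro group or the place it occupies on the ring also stays open, and a 3-chlorophenyl or a 2-methoxyphenyl on the same nitrogen would bear directly on that question.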